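This account rests on a few compounds, and the source may have more. Where it says the series, first, only, none or still open, it means among the compounds named here.

Measured so far:
compound 1 `Cn1ncc2c1[C@H](Cn1cnc3c(Cl)ncnc31)C[C@@H]2CO[Si](c1ccccc1)(c1ccccc1)C(C)(C)C` — 3.2 ug/mL
compound 2 `Cn1ncc2c1[C@H](Cn1cnc3c(Cl)nc(N)nc31)C[C@@H]2CO` — 3.2 ug/mL
compound 3 `COc1ncnc2c1ncn2C[C@@H]1C[C@H](CO)c2ccccc21` — 24 ug/mL

In a functional assay on MOLT-4 cells (Homo sapiens) (on this read-out lower numbers stand for stronger inhibition and higher numbers for weaker inhibition), compound 1 gives 3.2 ug/mL and compound 2 gives 3.2 ug/mL; these two values lie within the scatter of one another. Compound 3, at 24 ug/mL, stands highest of the three numbers, and its gap to compound 1 as well as to compound 2 is beyond the scatter, so compound 3 is the weakest inhibitor among the measured compounds.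

Compound 4 `OC[C@H]1C[C@@H](Cn2cnc3c(NC4CC4)ncnc32)c2ccccc21` is not yet measured in this assay. Relative to compound 3 it carries cyclopropylamino in place of methoxy on an aromatic carbon. For the measured compounds named here, no pair of measured compounds differing in one place is available, so no measured step gives a yardstick for a change of this kind; only the structural change and the position of compound 3 can be drawn on. A step toward a lower number, modest in size but beyond the scatter, is expected in this assay. Compound 4 is expected to give 10 ug/mL, with a range from 3.2 ug/mL to 32 ug/mL. The step that this estimate implies, a 2.4-fold lower number from compound 3 to compound 4 (0.38 log units; beyond the scatter), is thus expected to move compound 4 toward the values of compound 1 and compound 2 without necessarily reaching them.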

Compound 4, half-maximal inhibitory concentration: 24 ug/mL
Estimate against measurement, compound 4: 2.4-fold (0.38 log units) below; measured number inside the range.
By their numbers in this assay, from the lowest: compounds 1 and 2 (each within the scatter of the next); then compounds 3 and 4 (each within the scatter of the next).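

In this assay, for the compounds shown here, cyclopropylamino in place of methoxy on this aromatic carbon of the shared core gives no change at the digits printed from compound 3 to compound 4 (within the scatter), the only step that can be read at a single place. Going by these compounds alone, the position therefore accepts a group with more heavy atoms, a three-membered ring and a hydrogen-bond donor without a shift beyond the scatter, something the earlier compounds, none of which differ in one place, could not show. Nothing measured here offers an explanation for this flat step.

Still open, as far as these compounds go, is whether a morpholine ring or a longer chain such as butylamino on this carbon would move the number beyond the scatter. Also open, from the compounds shown here alone, is whether the same exchange of methoxy for cyclopropylamino would give a similar step on the core of compound 1.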